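The source may report more compounds than this note shows. Statements on the series, on what has been measured and on what is new or still open speak of the compounds shown alone.

Measured so far:
Compound 1 `CC1CCN(c2c(S(=O)(=O)c3cccc(F)c3)cnc3ccc(Cl)cc23)CC1` gives 58%
Compound 2 `COc1ccc2ncc(S(=O)(=O)c3cccc(F)c3)c(N3CCC(C)CC3)c2c1` gives 68%
Compound 3 `Cc1ccc2ncc(S(=O)(=O)c3cccc(F)c3)c(N3CCC(C)CC3)c2c1` gives 94%

These three numbers come from an assay on isolated protein for displacement of a labelled ligand from metabotropic glutamate receptor 5 (Homo sapiens), with a stated time of 60 min, tested at 1 uM; on this read-out lower numbers stand for less inhibition and higher numbers for more inhibition at the one concentration tested (going by the name of the read-out). Compound 1 has the lowest of the three; the step of a number 10 percentage points higher from compound 1 to compound 2 (within the scatter) stays within the scatter, while a number 36 percentage points higher from compound 1 to compound 3 (beyond the scatter) is large and a number 26 percentage points higher from compound 2 to compound 3 (beyond the scatter) is modest. All three measured steps change one substituent on an aromatic carbon of the shared core; the sulfonyl-bound 3-fluorophenyl is the same in every measured compound.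

Compound 4 `CC1CCN(c2c(S(=O)(=O)c3ccc(C#N)cc3)cnc3ccc(Cl)cc23)CC1` differs from compound 1 at a different place: 4-cyanophenyl in place of 3-fluorophenyl on a sulfonyl sulfur. For the measured compounds named here, none of the measured steps touches this part of the molecule, so none of them bears directly on the change. Going by the values given here, the only guidance is that compound 1 itself sits at the low end and that the measured steps elsewhere moved the number upward or left it within the scatter. With nothing to point in either direction, no step beyond the scatter is expected in this assay from compound 1 to compound 4.

The estimate for compound 4 in this assay is therefore 58%, with a range from 30% to 85%. The expected step of no change at the digits printed from compound 1 to compound 4 (within the scatter) reflects that uncertainty.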

Compound 4, a percentage reported as inhibition, at one concentration (the size of the read-out at that concentration, not a potency): 31%
Estimate against measurement, compound 4: 27 percentage points above, and the stated range covers the measured number.
By their numbers in this assay, from the lowest: compound 4; then compounds 1 and 2 (each within the scatter of the next); then compound 3.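

In this assay, for the compounds shown here, 4-cyanophenyl in place of 3-fluorophenyl on the sulfonyl sulfur gives a number 27 percentage points lower from compound 1 to compound 4 (beyond the scatter), so the group on the sulfonyl sulfur, which stayed the same in all the earlier compounds, can also move this read-out beyond the scatter. The swap alters two things at once, since the two groups differ both in what the phenyl ring carries, fluorine or a nitrile, and in the number that marks its place on that ring, so this one step cannot say which of the two matters. Nothing among the available data explains why the number moved in this direction.

A 3-cyanophenyl or a 4-fluorophenyl group on the sulfonyl sulfur would separate those two changes, and a plain phenyl group would show what the ring does without either substituent, but the compounds shown include none of these. Going by these compounds alone, also open is whether 4-cyanophenyl would have a similar effect on the methyl-bearing core of compound 3, which gives 94%, since this step was seen only on the chloro-bearing core.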